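The compounds below may be only part of what the source reports. "The series", "measured", "known", "first", "only" and "open" are said of these compounds alone.

Working notes on the series, cytotoxicity arm.

Compound 1 `Cc1ccc(NC(=O)Nc2cc(C)nc3ccccc23)cc1` is the urea carrying a 4-methylphenyl group on one amide-type nitrogen. In an ADME assay on BJ cells (Homo sapiens) for cytotoxicity, with a stated time of 72 h (a lower number here means that less compound is needed, a higher number that more compound is needed for the effect), compound 1 gives > 25000 nM, and that figure is a limit of the assay rather than a number. For the measured compounds named here, its one measured neighbour, compound 2 `Cc1cc(NC(=O)Nc2ncccc2C)c2ccccc2n1`, gives > 25000 nM in this assay, again a limit. The step that the two limits leave unreadable from compound 1 to compound 2 therefore cannot be read; both values sit at the limit of > 25000 nM in this assay, at which 2 of the 2 values shown sit, and nothing can be said of the size or direction of the change in going to 3-methylpyridin-2-yl from 4-methylphenyl.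

The next compound, compound 3 `Cc1cc(NC(=O)Nc2ccc(C(=O)O)cc2)c2ccccc2n1`, keeps the core of compound 1 and alters the pendant phenyl ring: carboxy in place of methyl on an aromatic carbon. Going by the values given here, no measured step touches this position, so there is no step of known size to lean on. With compound 1 at the limit in this assay, the expectation is that compound 3 also stays out of the measurable range, the expected step that the limit leaves unreadable from compound 1 to compound 3 amounting to no readable movement. Compound 3 is estimated at 40000 nM in this assay, with a range of 15000 nM to 150000 nM.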

Compound 3, half-maximal effective concentration: > 25000 nM
Compound 3 ended at the assay's limit; the forecaster's own chance of this, stated with the estimate: 85%; the middle value does not contradict the limit.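

No new step can be read from compound 3 in this assay, as the move from compound 1 to compound 3 runs between two limits of the assay and not between numbers: the limit of > 25000 nM in this assay, at which 3 of the 3 values shown sit.

The compounds shown leave open whether carboxy in place of methyl changes the cytotoxicity read-out at all, and in which direction.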